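A few compounds are considered here, and "the series" means these few. Any claim that something is new, unique, unknown or untested is made for them only; others in the source may bear on it.

Working notes on the series in a functional assay (aorta) for inhibition, with Rattus norvegicus as the target; on this read-out higher numbers stand for weaker inhibition and lower numbers for stronger inhibition.

Three compounds are measured. Compound 3 `CCCCN(CCCC)CCCOc1ccc(S(=O)(=O)c2c(C(C)C)nn3ccccc23)cc1` gives 31.1 nM. Compound 1 `CC(C)c1nn2ccccc2c1S(=O)(=O)c1ccc(OCCCNC(C)(C)C)cc1` gives 168 nM. Compound 2 `CCCCN(CCCC)CCCOc1ccc(S(=O)(=O)c2ccoc2C(C)C)cc1` gives 119 nM. Compound 2 and compound 1 lie within the scatter of each other; compound 3 stands apart from both, beyond the scatter.

Compound 1 differs from compound 3 only in the amine: (tert-butyl)amino in place of dibutylamino on a saturated chain carbon, three bonds along the chain from an oxygen on an aromatic ring. That change gave a 5.4-fold higher number from compound 3 to compound 1 (0.73 log units; beyond the scatter).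

Compound 4 `CC(C)c1occc1S(=O)(=O)c1ccc(OCCCNC(C)(C)C)cc1` has not yet been measured. It stands to compound 2 as compound 1 stands to compound 3: (tert-butyl)amino in place of dibutylamino on a saturated chain carbon, three bonds along the chain from an oxygen on an aromatic ring. The difference between the core of compound 2 and the core of compound 3 is not broken down here; the amine change is the same in both pairs and sits at the same place.

For compound 4 the expectation rests on a single precedent, the step from compound 3 to compound 1 given as a 5.4-fold higher number from compound 3 to compound 1 (0.73 log units; beyond the scatter), applied to compound 2 at 119 nM. Because a 5.4-fold higher number from compound 3 to compound 1 (0.73 log units; beyond the scatter) was modest but beyond the scatter, a step of similar size, weakened somewhat since it is carried over to a different core, is expected: a 4.6-fold higher number from compound 2 to compound 4 (0.66 log units; beyond the scatter). The number expected for compound 4 is 550 nM, within an estimated range from 230 nM to 1400 nM. One precedent on one core is thin ground; the estimate is provisional.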

Compound 4, half-maximal inhibitory concentration: 235 nM
For compound 4 the middle estimate is 2.3-fold (0.37 log units) above the measured one; the measured number falls inside the stated range.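

In this assay (tert-butyl)amino in place of dibutylamino gives a 2.0-fold higher number from compound 2 to compound 4 (0.30 log units; within the scatter), a step that cannot be told apart from the scatter of repeated measurements. The change therefore does not carry over at full size from one core to the other, and the two steps differ by more than their scatter: the same change on two cores in this assay, a 5.4-fold higher number (0.73 log units; beyond the scatter) from compound 3 to compound 1 and a 2.0-fold higher number (0.30 log units; within the scatter) from compound 2 to compound 4, 2.7-fold (0.44 log units) apart, beyond the scatter of two such steps. The printed numbers run the same way in both pairs, but on the core of compound 2 that direction lies within the scatter, and two pairs show neither why the cores differ nor how the change would behave on any further core.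

It stays open whether this gap between the cores would also appear with other amines, such as piperidine, pyrrolidine or diethylamino, or whether it is particular to the two amines shown here. A longer chain carrying the amine is also open, as is whether the core of compound 3 would keep its larger step with such a chain, since every compound shown has the same chain and each core is represented by only one pair.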